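Dropping a hydroxy group from two related selenium-ring compounds

The source may report more compounds than this note shows. Statements on the series, on what has been measured and on what is new or still open speak of the compounds shown alone.

Measured so far, in a functional assay on Hep 3B2 cells (Homo sapiens) for cytotoxicity, read by MTT assay, with a stated time of 48 h; on this read-out higher numbers stand for weaker inhibition and lower numbers for stronger inhibition:
compound 1 `COc1ccc2[nH]c(-c3ccc[se]3)cc(=O)c2c1O` gives 700 nM
compound 2 `COc1ccc2[nH]c(-c3ccc[se]3)cc(=O)c2c1` gives 3200 nM
compound 3 `COc1ccc2[nH]c(-c3cc[se]c3)cc(=O)c2c1O` gives 300 nM

All three share the same fused core and carry a five-membered ring holding one selenium atom; compound 1 and compound 3 hold the same atoms but join the five-membered ring to the core in a different way, as set out here: a group of 5 heavy atoms (4 carbon, 1 selenium; one five-membered aromatic ring with 1 hetero atom) in place of a group of 5 heavy atoms (4 carbon, 1 selenium; one five-membered aromatic ring with 1 hetero atom), on an aromatic carbon. That change gave a 2.3-fold lower number from compound 1 to compound 3 (0.37 log units; beyond the scatter), so compound 3 shows the lowest number of the three in this assay, and its distance from the others lies beyond the usual scatter.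

The second change is the loss of a hydroxy group from the core: hydrogen in place of hydroxy on an aromatic carbon. That step gave a 4.6-fold higher number from compound 1 to compound 2 (0.66 log units; beyond the scatter), a clear weakening.

Compound 4 `COc1ccc2[nH]c(-c3cc[se]c3)cc(=O)c2c1` has not yet been measured. It differs from compound 3 in exactly this way: hydrogen in place of hydroxy on an aromatic carbon. The place of the change is described in the same words as for the pair of compound 1 and compound 2, so this is the same change made on the other arrangement of the five-membered ring.

Going by the values given here, compound 4 is expected to show a 4.7-fold higher number from compound 3 to compound 4 (0.67 log units; beyond the scatter), resting on the size of a 4.6-fold higher number from compound 1 to compound 2 (0.66 log units; beyond the scatter) as the only measured example of this change. Compound 4 is therefore estimated at 1400 nM, most likely between 500 nM and 4000 nM.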

Compound 4, half-maximal inhibitory concentration: 3700 nM
Beside the measured number, compound 4's estimate is 2.6-fold (0.42 log units) below it, and the stated range covers the measured number.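

Taking away the hydroxy group raised the number on both arrangements of the five-membered ring in this assay, so the direction carried over, but with a 12-fold higher number from compound 3 to compound 4 (1.09 log units; beyond the scatter) the size did not: the same change on two cores in this assay, a 4.6-fold higher number (0.66 log units; beyond the scatter) from compound 1 to compound 2 and a 12-fold higher number (1.09 log units; beyond the scatter) from compound 3 to compound 4, 2.7-fold (0.43 log units) apart, beyond the scatter of two such steps

The change in how the five-membered ring is joined to the core carried over even less well, since the earlier lowering with the hydroxy group present has no counterpart without it, where the printed step is a 1.2-fold higher number from compound 2 to compound 4 (0.06 log units; within the scatter) and the two steps differ: the same change on two cores in this assay, a 2.3-fold lower number (0.37 log units; beyond the scatter) from compound 1 to compound 3 and a 1.2-fold higher number (0.06 log units; within the scatter) from compound 2 to compound 4, 2.7-fold (0.43 log units) apart, beyond the scatter of two such steps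

Within these four compounds, then, the effect of each change depends on the other, so a step measured on one core gives the direction of the hydroxy loss but not a reliable size on the other core; this does not show why the steps differ, or whether the same would hold beyond these two pairs.

The compounds shown leave open whether an amine or a fluorine atom in the place of the hydroxy group would behave more like the hydroxy group or more like hydrogen. They also leave open whether a five-membered ring with sulfur instead of selenium would show the same dependence between the two changes.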